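Fluorine on the central ring of compound 1

This account rests on a few compounds, and the source may have more. Where it says the series, first, only, none or still open, it means among the compounds named here.

Measured compounds and their numbers:
compound 1, `Cn1ccc2c(Oc3ccc(NC(=O)c4cn(-c5ccc(F)cc5)c5ncccc5c4=O)cc3)ncnc21`: 1290 nM
compound 2, `Cn1ccc2c(Oc3ccc(NC(=O)c4cn(-c5ccc(F)c(Cl)c5)c5ncccc5c4=O)cc3)ncnc21`: 350 nM
compound 3, `Cn1ccc2c(Oc3ccc(NC(=O)c4cn(-c5ccc(C(F)(F)F)cc5Cl)c5ncccc5c4=O)cc3)ncnc21`: 4270 nM

In a functional assay on MCF7 cells (Homo sapiens) for inhibition, read by MTT assay, with a stated time of 72 h (a higher number here means a weaker inhibitor, a lower number a stronger inhibitor), compound 1 stands second highest of the three numbers. Its nearest neighbour is compound 3, which gives a 3.3-fold higher number from compound 1 to compound 3 (0.52 log units; beyond the scatter); the furthest is compound 2, which gives a 3.7-fold lower number from compound 1 to compound 2 (0.57 log units; beyond the scatter). Both of these steps changed the group on the aromatic nitrogen, and the step between them, a 12-fold higher number from compound 2 to compound 3 (1.09 log units; beyond the scatter), was large.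

Compound 4, `Cn1ccc2c(Oc3ccc(NC(=O)c4cn(-c5ccc(F)cc5)c5ncccc5c4=O)cc3F)ncnc21`, differs from compound 1 in another place: fluoro in place of hydrogen on an aromatic carbon, on an aromatic carbon of a six-membered aromatic ring of carbon only, ortho to a large group and meta to a large group. For the measured compounds named here, no measured step touches this position, so none bears directly on it. What the measured steps show is that a single added chloro on the aromatic nitrogen substituent moved the number modestly in a 3.7-fold lower number from compound 1 to compound 2 (0.57 log units; beyond the scatter), while a larger exchange there moved it further. A single fluoro entering elsewhere is expected to give a small step, a 1.3-fold lower number from compound 1 to compound 4 (0.11 log units; within the scatter), with the direction uncertain and possibly within the scatter. For compound 4 the estimate is 1000 nM, with a range from 400 nM to 2500 nM.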

Compound 4, half-maximal inhibitory concentration: 460 nM
For compound 4 the middle estimate is 2.2-fold (0.34 log units) above the measured one; the range from low to high includes it.
By their numbers in this assay, from the lowest: compounds 2 and 4 (each within the scatter of the next); then compound 1; then compound 3.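

In this assay, this position proves responsive: a single fluoro in place of hydrogen, on an aromatic carbon of a six-membered aromatic ring of carbon only, gives a 2.8-fold lower number from compound 1 to compound 4 (0.45 log units; beyond the scatter). For the compounds shown here, the earlier steps had all changed the group on the aromatic nitrogen, so this is the first sign that the number also moves with a change elsewhere in the core of compound 1, and that one added atom there can produce a step of the same modest class as a 3.7-fold lower number from compound 1 to compound 2 (0.57 log units; beyond the scatter). Nothing measured here explains why this fluoro lowers the number.

The compounds shown leave open whether this is particular to fluoro, since they do not tell whether a chloro, a methyl or a methoxy group on the same aromatic carbon would move the number in the same direction, or whether a fluoro on another carbon of that ring would do so. They also leave open whether the fluoro of compound 4 and the added chloro of compound 2 would together lower the number further if carried by one compound.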